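Isomeric amine swap in the solubility series

The source may hold more compounds than are shown below. What is called first, only, known or untested is meant among the compounds shown, and "the series" means these compounds.

The study measures solubility in a physicochemical assay for solubility, read by spectrophotometry, in phosphate buffer, with a stated time of 2 h, at pH 7.4; on this read-out lower numbers stand for lower solubility and higher numbers for higher solubility. Compound 1 `COc1ccc2[nH]c(C(=O)N3CC(=O)N(Cc4ccccc4)[C@@H](CCN4CCC5(CC4)CC5)C3)cc2c1` reaches only a limit of the assay in this assay, giving > 25000 nM without a number. Compound 2 `COc1ccc2[nH]c(C(=O)N3CC(=O)N(Cc4c[nH]c5ccccc45)[C@@H](Cc4ccccc4)C3)cc2c1` gives 10300 nM in this assay, and compound 3 `COc1cccc(CN2C(=O)CN(C(=O)c3cc4cc(OC)ccc4[nH]3)C[C@@H]2Cc2ccccn2)c1` gives 57900 nM in this assay, so compound 3 sits higher than compound 2. Compound 1 stands at the limit, as noted in the limit of > 25000 nM in this assay, at which 1 of the 3 values shown sits, so its place relative to the other two cannot be fixed. Compound 4 `COc1ccc2[nH]c(C(=O)N3CC(=O)N(Cc4ccccc4)[C@@H](CN4CC5CCCCC5C4)C3)cc2c1` has the same atoms as compound 1, joined differently: a group of 9 heavy atoms (8 carbon, 1 nitrogen; one five-membered non-aromatic ring with 1 hetero atom, one six-membered non-aromatic ring of carbon only) in place of a group of 9 heavy atoms (8 carbon, 1 nitrogen; one three-membered non-aromatic ring of carbon only, one six-membered non-aromatic ring with 1 hetero atom), on a saturated chain carbon bound to a saturated ring carbon. For the measured compounds named here, no step between measured compounds is available, and the two amines are of the same size and carry the same single acceptor, so no direction beyond the scatter is expected; compound 4 is estimated to stay near the limit, with the step of a number no higher from compound 1 to compound 4 (the limit leaves the size open) expected to lie within the scatter. In this assay compound 4 is expected to give about 25000 nM, between 10000 nM and 60000 nM.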

Compound 4, solubility: 23800 nM
Compound 4: the middle estimate sits 1.1-fold (0.02 log units) above what was measured; low and high end bracket the measured number.
By their numbers in this assay, from the lowest: compound 2; then compound 4; then compound 3.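

Compound 1 gave only a limit at this position. In this assay compound 4 gives 23800 nM, which gives this position a number. Exchanging the group with the three-membered carbon ring and six-membered ring with 1 hetero atom for the group with the five-membered ring with 1 hetero atom and six-membered carbon ring, on a saturated chain carbon bound to a saturated ring carbon, gives an at least 1.0-fold lower number from compound 1 to compound 4 (0.02 log units; that floor lies within the scatter), so only a floor for this change can be read. The true size of the step stays open, and what holds it open is the limit on the side of compound 1: the limit of > 25000 nM in this assay, at which 1 of the 4 values shown sits.

As far as these compounds go, it remains open how an open-chain amine such as diethylamine, or a carboxylic acid, would read at this position. From the compounds shown here alone, it is also open whether the same exchange of amines would give a similar step with a different group on the ring nitrogen of the shared core.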